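Halogen swap on the terminal ring of the amidine series

This account rests on a few compounds, and the source may have more. Where it says the series, first, only, none or still open, it means among the compounds named here.

Three amidines share one core. In a functional assay on RPMI-8226 cells (Homo sapiens) for inhibition, read by sulforhodamine B assay, with a stated time of 48 h (a higher number here means a weaker inhibitor of growth, a lower number a stronger inhibitor of growth), compound 1 `N=C(N)c1ccc(-c2ccc(-c3cc(Cl)cc(Cl)c3)s2)cc1` gives 639 nM, compound 2 `N=C(N)c1ccc(-c2ccc(-c3ccc(F)cc3)s2)cc1` gives 799 nM, and compound 3 `COc1cc(OC)cc(-c2ccc(-c3ccc(C(=N)N)cc3)s2)c1` gives 1460 nM. Compound 2 lies within the scatter of both compound 1 and compound 3, so no order among the three can be read from these numbers. Compound 4 `N=C(N)c1ccc(-c2ccc(-c3ccc(Cl)cc3)s2)cc1` has not yet been measured. Relative to compound 2 it differs by chloro in place of fluoro on an aromatic carbon. Going by the values given here, no measured pair shows this exchange, so only a small step is expected: the estimated size, a 1.2-fold lower number from compound 2 to compound 4 (0.09 log units; within the scatter), stays within the scatter, leaning if anything toward a lower number. For compound 4 the expected value in this assay is 650 nM, with a range from 350 nM to 1200 nM.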

Compound 4, concentration for 50% growth inhibition: 194 nM
The estimate for compound 4 lay 3.4-fold (0.53 log units) above the measured number, and the stated range ends above it.
By their numbers in this assay, from the lowest: compound 4; then compounds 1, 2 and 3 (each within the scatter of the next, the first and the last beyond it).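

Going by these compounds alone, on the terminal ring, 4-fluorophenyl to 4-chlorophenyl is the first exchange confined to one place: in this assay it gives a 4.1-fold lower number from compound 2 to compound 4 (0.61 log units; beyond the scatter) and lies beyond the scatter. Within the data shown here, the site para to a large group therefore responds to which halogen it carries, something the earlier compounds could not show. Nothing at hand accounts for this step. From the compounds shown here alone, whether bromo, methyl or an amine at this site would give a lower or higher number stays open. So does whether the step persists with a carboxylic acid in place of the amidine.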